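Chloro for fluoro on the fused benzene of compound 2

This account rests on a few compounds, and the source may have more. Where it says the series, first, only, none or still open, it means among the compounds named here.

Compound 1 `CC(C)n1c(/C=C2/C(=O)Nc3ccccc32)nc2ccccc21` is the unsubstituted parent of the pair measured so far; in a functional assay on PC-3 cells (Homo sapiens) for cytotoxicity, read by MTT assay, with a stated time of 48 h (on this read-out lower numbers stand for stronger inhibition and higher numbers for weaker inhibition), compound 1 gives 37600 nM. Compound 2 `CC(C)n1c(/C=C2/C(=O)Nc3ccc(F)cc32)nc2ccccc21` carries a fluoro on an aromatic carbon of the same ring, and in this assay compound 2 gives 20800 nM. The step of a 1.8-fold lower number from compound 1 to compound 2 (0.26 log units; within the scatter) is the only one recorded. Compound 2 thus holds the lowest of the two numbers, but its distance to compound 1 is within the scatter, so no order between the two is claimed.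

Compound 3 `CC(C)n1c(/C=C2/C(=O)Nc3ccc(Cl)cc32)nc2ccccc21` differs from compound 2 by chloro in place of fluoro on an aromatic carbon. For the measured compounds named here, no measured pair covers this exchange of one halogen for another; the only step touching this carbon is a 1.8-fold lower number from compound 1 to compound 2 (0.26 log units; within the scatter), which stayed within the scatter. On that basis no step beyond the scatter is expected in this assay for compound 3, with at most a slight drift toward a lower number. Compound 3 is estimated at 15000 nM, with a range from 5000 nM to 45000 nM. This estimate corresponds to an expected step of a 1.4-fold lower number from compound 2 to compound 3 (0.14 log units; within the scatter), judged to lie within the scatter.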

Compound 3, half-maximal inhibitory concentration: 38100 nM
Compound 3: the middle estimate sits 2.5-fold (0.40 log units) below what was measured; measured number inside the range.
By their numbers in this assay, from the lowest: compounds 2, 1 and 3 (each within the scatter of the next).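

In this assay the exchange of one halogen for the other gives a 1.8-fold higher number from compound 2 to compound 3 (0.26 log units; within the scatter) and stays within the scatter, and chloro in place of hydrogen gives a 1.0-fold higher number from compound 1 to compound 3 (0.01 log units; within the scatter) and also stays within the scatter. The earlier pair covered only fluoro against hydrogen; with chloro as a second halogen on this aromatic carbon, all three pairs among compound 1, compound 2 and compound 3 lie within the scatter. Hydrogen, fluoro and chloro at this place are therefore not told apart by this read-out, and no trend running from hydrogen through fluoro to chloro can be claimed. No supporting measurement bears on this result.

Still open, going by these compounds, is whether a different kind of group on this aromatic carbon, such as an amine, a carboxylic acid or a methoxy group, would give a step beyond the scatter from compound 1. Also open, on these data alone, is whether the same lack of separation among hydrogen, fluoro and chloro would hold on other cell lines or at exposure times other than the one stated.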